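The compounds below may be only part of what the source reports. "The series", "measured", "known", "first", "only" and "open" are said of these compounds alone.

Compound 3 `CC(C)C(c1cnc(N)s1)c1ccc(-c2ccc3cccc(F)c3c2)[nH]c1=O` gives 39 nM in a functional assay on CHO cells for antagonist activity at prostaglandin E2 receptor EP3 subtype (Homo sapiens), read by cAMP accumulation (on this read-out higher numbers stand for weaker inhibition and lower numbers for stronger inhibition), the smallest of the three numbers shown, though only by margins within the scatter. Compound 1 `CC(C)C(c1ncco1)c1ccc(-c2ccc3cccc(F)c3c2)[nH]c1=O` gives 64 nM and compound 2 `Cc1nc(C(c2ccc(-c3ccc4cccc(F)c4c3)[nH]c2=O)C(C)C)[nH]c1C` gives 50 nM; the steps of a 1.6-fold lower number from compound 1 to compound 3 (0.22 log units; within the scatter) and a 1.3-fold lower number from compound 2 to compound 3 (0.11 log units; within the scatter) both stay within the scatter. Compound 4 `CC(C)C(c1noc(=O)[nH]1)c1ccc(-c2ccc3cccc(F)c3c2)[nH]c1=O` differs from compound 3 by a group of 6 heavy atoms (2 carbon, 2 nitrogen, 2 oxygen; one five-membered aromatic ring with 3 hetero atoms) in place of a group of 6 heavy atoms (3 carbon, 2 nitrogen, 1 sulfur; one five-membered aromatic ring with 2 hetero atoms), on a saturated chain carbon bound to an aromatic carbon and a saturated chain carbon. All three measured steps exchange a five-membered heteroaryl at this same saturated chain carbon, and none of them moves beyond the scatter, so no step beyond the scatter is expected for compound 4 either. Compound 4 is therefore expected to give about 50 nM in this assay, within a range from 20 nM to 130 nM, a step of a 1.3-fold higher number from compound 3 to compound 4 (0.11 log units; within the scatter).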

Compound 4, half-maximal inhibitory concentration: 41 nM
Compound 4: middle estimate off by 1.2-fold (0.09 log units), on the high side; measured number inside the range.
By their numbers in this assay, from the lowest: compounds 3, 4, 2 and 1 (each within the scatter of the next).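

In this assay, the five-membered aromatic ring with 3 hetero atoms stays within the scatter of all three earlier heteroaryl groups (a 1.1-fold higher number from compound 3 to compound 4 (0.02 log units; within the scatter); a 1.2-fold lower number from compound 2 to compound 4 (0.09 log units; within the scatter); a 1.6-fold lower number from compound 1 to compound 4 (0.19 log units; within the scatter)). At this saturated chain carbon, the exchange thus extends to a ring with a double bond outside it and no sulfur, and still yields no step beyond the scatter. Nothing available explains this flat outcome. From the compounds shown here alone, whether a phenyl ring, a carboxylic acid or an open-chain amine on this carbon would move the number beyond the scatter remains open. So does whether the isopropyl-bearing carbon tolerates these rings with another group in place of the fluoronaphthyl part.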